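Swapping one aryl group, with activity expected to stay weak

This account rests on a few compounds, and the source may have more. Where it says the series, first, only, none or still open, it means among the compounds named here.

Measured so far:
compound 1, `Cc1cc(C)cc(-n2nncc2CN2C(=O)C3(C(C#N)=C(N)Oc4c3c3nc5ccccc5nc3c3ccccc43)c3ccccc32)c1`, gives > 50000 nM in a functional assay on HCT-116 cells (Homo sapiens) for antiproliferative activity, read by MTT assay, with a stated time of 48 h; on this read-out lower numbers stand for stronger inhibition and higher numbers for weaker inhibition.
compound 2, `N#CC1=C(N)Oc2c(N)cc3nc4ccccc4nc3c2C12C(=O)N(Cc1cnnn1-c1cccc(C(F)(F)F)c1)c1ccccc12`, gives 18900 nM in this assay.

The number for compound 1 is a limit of this assay, not a measured value; (the limit of > 50000 nM in this assay, at which 1 of the 2 values shown sits). Going by the values given here, compound 2 therefore stands as the only full number here, and it marks weak inhibition. Compound 3, `Cc1ccc(C)c(-n2nncc2CN2C(=O)C3(C(C#N)=C(N)Oc4c(N)cc5nc6ccccc6nc5c43)c3ccccc32)c1`, differs from compound 2 in one place: 2,5-dimethylphenyl in place of 3-(trifluoromethyl)phenyl on an aromatic nitrogen. Among the compounds with values here, no measured pair shows this change, so the step of a 1.6-fold higher number from compound 2 to compound 3 (0.20 log units; within the scatter) is expected to be small, leaning toward slightly weaker inhibition. Compound 3 is estimated at 30000 nM, within 8000 nM to 70000 nM.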

Compound 3, half-maximal inhibitory concentration: > 50000 nM
Compound 3: no number, only a limit (the forecaster's own chance of this, stated with the estimate: 35%); middle value at least 1.6-fold (0.22 log units) away from the limit.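

Placing 2,5-dimethylphenyl in place of 3-(trifluoromethyl)phenyl on the aromatic nitrogen gives an at least 2.6-fold higher number from compound 2 to compound 3 (0.42 log units; beyond the scatter) in this assay, the first readable sign that the aryl group at this position matters. As far as these compounds go, compound 3 gives > 50000 nM, which is a limit and not a number, so the full size of the step stays unknown. This limit now accounts for most of the results: the limit of > 50000 nM in this assay, at which 2 of the 3 values shown sit.

From the compounds shown here alone, it remains open whether an amine or a carboxylic acid on this phenyl ring would give stronger inhibition than compound 2. The compounds shown also cannot separate losing the trifluoromethyl group from gaining the methyl groups.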